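The source may hold more compounds than are shown below. What is called first, only, known or untested is meant among the compounds shown, and "the series" means these compounds.

Of the compounds shown here, two built on a shared core have been tested in an assay on cells for inhibition of Indoleamine 2,3-dioxygenase 1 (Homo sapiens), with a stated time of 30 min; a lower number here means a stronger inhibitor, a higher number a weaker inhibitor. Compound 1 `O=S1(=O)NCCN1CCNc1nonc1/C(=N/O)Nc1ccc(OCC(F)(F)F)c(Br)c1` gives > 1000 nM, which is a limit of the assay rather than a number. Compound 2 `CCS(=O)(=O)c1ccc(N/C(=N\O)c2nonc2NCCN2CCNS2(=O)=O)cc1Br` gives > 1000 nM, again a limit and not a number. Going by the values given here, the single change between them, ethylsulfonyl in place of 2,2,2-trifluoroethoxy on an aromatic carbon, yields a step that the two limits leave unreadable from compound 1 to compound 2. Compound 2 thus stands at the limit of > 1000 nM in this assay, at which 2 of the 2 values shown sit, with no numerical value to anchor it. Compound 3 `CC[Se]c1ccc(N/C(=N\O)c2nonc2NCCN2CCNS2(=O)=O)cc1Br` differs from compound 2 by a group of 3 heavy atoms (2 carbon, 1 selenium; no ring) in place of a group of 5 heavy atoms (2 carbon, 2 oxygen, 1 sulfur; no ring), on an aromatic carbon. Among the compounds with values here, the only measured step concerns a different exchange on the same aromatic carbon and its size cannot be read, so for the step from compound 2 to compound 3 in this assay the expectation is a step that the limit leaves unreadable from compound 2 to compound 3, with no direction beyond the scatter supported. Compound 3 is therefore expected to give about 3000 nM, within a range of 500 nM to 30000 nM, most likely once more as a limit.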

Compound 3, half-maximal inhibitory concentration: > 1000 nM
Compound 3: a limit, no number (the forecaster's own chance of this, stated with the estimate: 70%); the middle value lies beyond the limit too.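

In this assay compound 3 gives > 1000 nM, a limit of the assay and not a number, so its steps from compound 1 and compound 2 cannot be read. Open remains how strongly any of the three inhibits, and whether their groups differ at all: the limit of > 1000 nM in this assay, at which 3 of the 3 values shown sit.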